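This account rests on a few compounds, and the source may have more. Where it says the series, first, only, none or still open, it means among the compounds named here.

Among the compounds with values here, in a physicochemical assay for solubility, measured as kinetic solubility, at pH 6.5 (on this read-out higher numbers stand for higher solubility and lower numbers for lower solubility), compound 3 `COc1ccc(-c2cc(-c3ccc(S(C)(=O)=O)cc3)cnc2N)cn1` gives 121 ug/mL, the highest number so far. Compound 1 `COc1ccc(-c2cc(-c3ccc(S(C)(=O)=O)cc3)cnc2NCCCCN)cn1` gives 25 ug/mL. Compound 2 `CCOc1ncc(-c2ccc(S(C)(=O)=O)cc2)cc1-c1ccc(OC)nc1` returns only a limit, < 1.6 ug/mL, not a true number.

Compound 4 `CNc1ncc(-c2ccc(S(C)(=O)=O)cc2)cc1-c1ccc(OC)nc1` has not yet been measured. It differs from compound 3 in one place: methyl in place of hydrogen on a nitrogen on an aromatic ring.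

The most relevant comparison changes the same nitrogen, and compound 1 carries 4-aminobutyl there. That comparison shows a 4.8-fold higher number from compound 1 to compound 3 (0.68 log units; beyond the scatter), so hydrogen gave the higher number in this one pair. Two further steps replace the whole amino-type group with ethoxy and reach the limit: an at least 15-fold lower number from compound 1 to compound 2 (1.19 log units; beyond the scatter) and an at least 75-fold higher number from compound 2 to compound 3 (1.87 log units; beyond the scatter). They bear less directly, since compound 4 keeps its nitrogen.

In this assay, a modest drop is therefore expected, not a large one. The estimated change is a 3.5-fold lower number from compound 3 to compound 4 (0.54 log units; beyond the scatter). Compound 4 is expected to give about 35 ug/mL, with an estimated range of 8 ug/mL to 120 ug/mL.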

Compound 4, solubility: 12.5 ug/mL
Compound 4: the middle estimate sits 2.8-fold (0.45 log units) above what was measured; the measured number falls inside the stated range.
By their numbers in this assay, from the lowest: compounds 4 and 1 (each within the scatter of the next); then compound 3. At a limit, below all of these: compound 2.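

On the nitrogen on an aromatic ring, one methyl in place of hydrogen is enough for a clear change in this assay, with a 9.7-fold lower number from compound 3 to compound 4 (0.99 log units; beyond the scatter). The longer 4-aminobutyl had already shown a step in this direction, but the size of the group on this nitrogen now gives no readable separation, with a 2.0-fold lower number from compound 1 to compound 4 (0.30 log units; within the scatter), so among these compounds only the unsubstituted amino group stands apart. Methylamino in place of ethoxy gives an at least 7.8-fold higher number from compound 2 to compound 4 (0.89 log units; beyond the scatter), but that step starts from a limit and not a true number: the limit of < 1.6 ug/mL in this assay, at which 1 of the 4 values shown sits.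

The compounds shown leave open whether ethylamino or dimethylamino would fall with the methylamino and 4-aminobutyl compounds. They also do not show whether a chain of intermediate length, or one ending in a carboxylic acid, would behave the same way.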